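This account rests on a few compounds, and the source may have more. Where it says the series, first, only, none or still open, it means among the compounds named here.

In a functional assay on KYSE-510 cells (Homo sapiens) for antiproliferative activity, read by crystal violet staining, with a stated time of 96 h (on this read-out lower numbers stand for stronger inhibition of growth and higher numbers for weaker inhibition of growth), compound 2, with the structure `O=S(=O)(NC1=NCCN1C(=S)SN1CCn2c1nsc2=S)c1ccc(C(F)(F)F)cc1`, reaches only a limit of the assay and gives >= 20000 nM. Its closest relative, compound 1 with the structure `COc1cc(C)ccc1S(=O)(=O)NC1=NCCN1C(=S)SN1CCn2c1nsc2=S`, likewise stops at a limit of the assay in this assay and gives >= 20000 nM. For the measured compounds named here, the one measured step between them, a step that the two limits leave unreadable from compound 1 to compound 2, cannot be read, and the reason is the limit of >= 20000 nM in this assay, at which 2 of the 2 values shown sit. The move from compound 2 to compound 3, which has the structure `COc1cccc(S(=O)(=O)NC2=NCCN2C(=S)SN2CCn3c2nsc3=S)c1`, is 3-methoxyphenyl in place of 4-(trifluoromethyl)phenyl on a sulfonyl sulfur. Going by the values given here, no measured step shows how a change on this sulfonyl sulfur affects growth inhibition in this assay, and the two known values both sit at the same limit, so no step beyond the scatter is expected in either direction. On that basis compound 3 is expected to sit near the same limit, at an estimated 20000 nM with a range from 8000 nM to 40000 nM, which would mean an expected step of a number no higher from compound 2 to compound 3 (the limit leaves the size open).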

Compound 3, concentration for 50% growth inhibition: >= 20000 nM
Compound 3 ended at the assay's limit; the forecaster's own chance of this, stated with the estimate: 80%; the middle value sits exactly at the limit.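

No size can be read for the steps from compound 1 and from compound 2 to compound 3, because all three compounds stop at one limit: the limit of >= 20000 nM in this assay, at which 3 of the 3 values shown sit. The compounds shown leave open which group on the sulfonyl sulfur, if any, would give a measurable value in this assay.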